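This account rests on a few compounds, and the source may have more. Where it says the series, first, only, none or still open, it means among the compounds named here.

Working notes on the series. Compound 1 `O=C(CCCCCN1C(=O)CC(SCCOCCOCCOc2cc(O)c(C(=O)CCc3ccc(O)cc3)c(O[C@@H]3O[C@H](CO)[C@@H](O)[C@H](O)[C@H]3O)c2)C1=O)OCn1cc(F)c(=O)[nH]c1=O` is the full conjugate. In a functional assay on HCT-116 cells (Homo sapiens) for cytotoxicity, read by sulforhodamine B assay, with a stated time of 48 h, in the presence of a further agent that is not named here (on this read-out higher numbers stand for weaker inhibition and lower numbers for stronger inhibition), compound 1 gives > 100000 nM, a limit of the measurement rather than a number. Compound 2 `O=C(CCCCCN1C(=O)CC(SCCOCCOCCOc2cc(O)c(C(=O)CCc3ccc(O)cc3)c(O)c2)C1=O)OCn1cc(F)c(=O)[nH]c1=O` differs from it by hydrogen in place of 3,4,5-trihydroxy-6-(hydroxymethyl)oxan-2-yl on an oxygen on an aromatic ring; in this assay compound 2 gives 82800 nM. The step is an at least 1.2-fold lower number from compound 1 to compound 2 (0.08 log units; that floor lies within the scatter), and only its floor is known because compound 1 sits at the limit of > 100000 nM in this assay, at which 2 of the 3 values shown sit. Compound 3 `O=C(CCc1ccc(O)cc1)c1c(O)cc(OCCOCCOCCS)cc1O[C@@H]1O[C@H](CO)[C@@H](O)[C@H](O)[C@H]1O` is the thiol fragment; how its core differs from that of compound 1 is not broken down here. In this assay compound 3 gives > 100000 nM, again a limit and not a number. Compound 4 `O=C(CCc1ccc(O)cc1)c1c(O)cc(OCCOCCOCCS)cc1O` is not yet measured and differs from compound 3 by hydrogen in place of 3,4,5-trihydroxy-6-(hydroxymethyl)oxan-2-yl on an oxygen on an aromatic ring, the place reading the same in both pairs. For compound 4 a step that the limit leaves unreadable from compound 3 to compound 4 is expected, set beside the earlier step. That rests on the same change having shown only a floor between compound 1 and compound 2, and on where compound 3 stands. Compound 4 is estimated at 120000 nM, within 50000 nM to 300000 nM, with a further limit rather than a number quite likely.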

Compound 4, half-maximal inhibitory concentration: 15900 nM
Beside the measured number, compound 4's estimate is 7.5-fold (0.88 log units) above it; the measured number lies below the stated range.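

In this assay, hydrogen in place of 3,4,5-trihydroxy-6-(hydroxymethyl)oxan-2-yl gives an at least 6.2-fold lower number from compound 3 to compound 4 (0.79 log units; beyond the scatter), so on the core of compound 3 the change lowers the number beyond the scatter. Both steps are known only as floors: the same change on two cores in this assay, an at least 1.2-fold lower number (0.08 log units; that floor lies within the scatter) from compound 1 to compound 2 and an at least 6.2-fold lower number (0.79 log units; beyond the scatter) from compound 3 to compound 4; the limit leaves it open whether they differ The result therefore shows neither that the size of the change carries over from one core to the other nor that it differs between them.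

From the compounds shown here alone, the true size of each step remains open, since compound 1 and compound 3 stand at limits. Also open, going by these compounds, is what a methyl group or a longer chain ending in a carboxylic acid would do on that same oxygen in place of the 3,4,5-trihydroxy-6-(hydroxymethyl)oxan-2-yl group.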